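Pyrrolidine amides: swapping a chlorophenyl for a phenoxy group

The source may hold more compounds than are shown below. What is called first, only, known or untested is meant among the compounds shown, and "the series" means these compounds.

Measured compounds:
- compound 1 `Cc1ccc(CCCCCCC(=O)N2CCCC2)cc1`: 9600 nM
- compound 2 `O=C(CCc1ccc(-c2cccc(Cl)c2)cc1)N1CCCC1`: 25400 nM
- compound 3 `O=C(CCCCCCC1CCCCC1)N1CCCC1`: 5700 nM

All three share a pyrrolidine amide core and were tested in an assay on HEK293 cells for inhibition of N-acylethanolamine-hydrolyzing acid amidase (Rattus norvegicus), read by LC-MS, with a stated time of 30 min; on this read-out lower numbers stand for stronger inhibition and higher numbers for weaker inhibition. Compound 2 gives the highest number of the three, so it is the weakest inhibitor here. Its nearest neighbour is compound 1, whose number is lower by a gap beyond the scatter, and compound 3 sits furthest away, again beyond the scatter.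

The unmeasured compound 4 `O=C(CCc1ccc(Oc2ccccc2)cc1)N1CCCC1` differs from compound 2 in one place: phenoxy in place of 3-chlorophenyl on an aromatic carbon. Among the measured compounds shown here, no measured pair shows the effect of this exact change, so there is no direct yardstick. Given that compound 2 sits at 25400 nM, the expected step in this assay is a small one, probably within the scatter or slightly toward a lower number, expressed as a 1.4-fold lower number from compound 2 to compound 4 (0.15 log units; within the scatter). For compound 4 the estimated value is 18000 nM, with an expected range from 6000 nM to 50000 nM.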

Compound 4, half-maximal inhibitory concentration: > 100000 nM
Compound 4 was reported as a limit (the forecaster's own chance of this, stated with the estimate: 15%); at least 5.5-fold (0.74 log units) between middle value and limit.
By their numbers in this assay, from the lowest: compounds 3 and 1 (each within the scatter of the next); then compound 2. At a limit, above all of these: compound 4.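

At this aromatic carbon, phenoxy cannot stand in for 3-chlorophenyl without a cost: in this assay, the swap gives an at least 3.9-fold higher number from compound 2 to compound 4 (0.59 log units; beyond the scatter). The two groups have the same count of heavy atoms and each holds one six-membered aromatic ring of carbon only, so matching those counts was not enough to keep the inhibition seen with compound 2. The value of compound 4 is a limit and not a number: the limit of > 100000 nM in this assay, at which 1 of the 4 values shown sits.

The compounds shown leave open whether the loss goes with the oxygen that joins the two rings or with the missing chlorine, and a plain phenyl or a 3-chlorophenoxy group at this place would separate the two. They also leave open what an amine or a carboxylic acid on the outer ring would do.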